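Swapping the amine substituent on the piperidine of compound 1

The source may hold more compounds than are shown below. What is called first, only, known or untested is meant among the compounds shown, and "the series" means these compounds.

Compound 1 `COC[C@H](NC1CCN(CCCc2c[nH]c3ccc(-n4cnnc4)cc23)CC1)c1ccccc1` shows the highest maximal response of the three measured compounds in a functional assay on CHO cells for activation of 5-hydroxytryptamine receptor 1D (Homo sapiens), read by GTPgammaS binding (on this read-out higher numbers stand for larger maximal responses and lower numbers for smaller maximal responses), giving 93%. Compound 3 `OC[C@H](NC1CCN(CCCc2c[nH]c3ccc(Cn4cncn4)cc23)CC1)c1ccccc1` comes nearest to it with 76% in this assay, while compound 2 `CC(=O)Nc1ccc(CNC2CCN(CCCc3c[nH]c4ccc(-n5cnnc5)cc34)CC2)cc1` gives 75% in this assay; both differ from compound 1 by more than the usual scatter. Compound 4 `CC(C)=CCN(C)C1CCN(CCCc2c[nH]c3ccc(-n4cnnc4)cc23)CC1` is not yet measured and differs from compound 1 by methyl(3-methylbut-2-en-1-yl)amino in place of (2-methoxy-1-phenylethyl)amino on a saturated ring carbon. Within the data shown here, only one measured step bears on this change: a number 18 percentage points lower from compound 1 to compound 2 (beyond the scatter), which also replaces the substituent on the same amine nitrogen and lowers the response modestly. The step to compound 4 exchanges the whole amine substituent for a smaller, ring-free one, so a reduction of similar or somewhat larger size is expected in this assay rather than none beyond the scatter. Compound 4 is therefore expected to give about 75% in this assay, with a range from 55% to 95%, an expected step of a number 18 percentage points lower from compound 1 to compound 4 (beyond the scatter).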

Compound 4, largest response reached (reported as efficacy), in percent of the reference or control that the assay uses: 115%
The estimate for compound 4 lay 40 percentage points below the measured number, and the stated range ends below it.
By their numbers in this assay, from the lowest: compounds 2 and 3 (each within the scatter of the next); then compound 1; then compound 4.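

In this assay the exchange of (2-methoxy-1-phenylethyl)amino for methyl(3-methylbut-2-en-1-yl)amino gives a number 22 percentage points higher from compound 1 to compound 4 (beyond the scatter), so changes at this saturated ring carbon can raise the maximal response as well as lower it, whereas the earlier step on this amine, a number 18 percentage points lower from compound 1 to compound 2 (beyond the scatter), went down. The substituent of compound 4 has no ring, no defined stereocentre and no hydrogen-bond donor, so none of these features of compound 1 is required for a high response on this core. Nothing shown here explains the rise.

On these data alone, the entering group differs in its methyl on nitrogen, its double bond and its lack of a ring all at once, so which of these goes with the rise stays open. A saturated 3-methylbutyl chain in place of the 3-methylbut-2-en-1-yl group, or a hydrogen in place of that methyl, would separate these features.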